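The source may hold more compounds than are shown below. What is called first, only, known or untested is meant among the compounds shown, and "the series" means these compounds.

In a functional assay on MCF7 cells (Homo sapiens) for antiproliferative activity, read by MTT assay, with a stated time of 72 h (on this read-out higher numbers stand for weaker inhibition and lower numbers for stronger inhibition), compound 1 `O=S(=O)(Oc1ccc(Br)cc1)C1CC2OC1C(c1ccc(/C=C/c3cc(O)cc(O)c3)cc1)=C2c1ccc(O)cc1` gives 16900 nM and compound 2 `Cc1ccc(OS(=O)(=O)C2CC3OC2C(c2ccc(/C=C/c4cc(O)cc(O)c4)cc2)=C3c2ccc(O)cc2)cc1` gives 9200 nM, which places the two within the scatter of each other. Compound 3 `O=S(=O)(Oc1cccc2ccccc12)C1CC2OC1C(c1ccc(/C=C/c3cc(O)cc(O)c3)cc1)=C2c1ccc(O)cc1` carries naphthalen-1-yl in place of 4-methylphenyl on an oxygen. Among the compounds with values here, the only measured step, a 1.8-fold lower number from compound 1 to compound 2 (0.26 log units; within the scatter), exchanges bromo for methyl on an aromatic carbon and is a weak guide, as no measured compound carries naphthalen-1-yl. A shift beyond the scatter is therefore not expected in this assay. The estimated change is a 1.0-fold lower number from compound 2 to compound 3 (0.01 log units; within the scatter). For compound 3 the expected value is 9000 nM, with an estimated range of 3500 nM to 22000 nM.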

Compound 3, half-maximal inhibitory concentration: 11000 nM
Compound 3: middle estimate off by 1.2-fold (0.09 log units), on the low side; the measured number falls inside the stated range.
By their numbers in this assay, from the lowest: compounds 2, 3 and 1 (each within the scatter of the next).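

In this assay, putting naphthalen-1-yl on an oxygen whose other neighbour is the sulfonyl sulfur gives a 1.2-fold higher number from compound 2 to compound 3 (0.08 log units; within the scatter) and, against the 4-bromophenyl compound, a 1.5-fold lower number from compound 1 to compound 3 (0.19 log units; within the scatter). A second six-membered aromatic ring at this place therefore moves the number no further than a change of substituent on the single ring did. No evidence is available that accounts for this result.

All three groups here are aromatic rings of carbon only. As far as these compounds go, whether a pyridine ring, a carboxylic acid on the ring or a simple alkyl chain at this oxygen would shift the number beyond the scatter remains open.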